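This account rests on a few compounds, and the source may have more. Where it says the series, first, only, none or still open, it means among the compounds named here.

Working notes on the series. Of the compounds shown here, three have been measured in an in vitro functional assay on HEK285-7 cells for antagonist activity at prostaglandin D2 receptor 2 (Homo sapiens), read by BRET and beta-arrestin recruitment; on this read-out lower numbers stand for stronger inhibition and higher numbers for weaker inhibition. Compound 1 `O=C(O)Cc1sc(NCc2ccccc2)nc1-c1ccc(Cl)cc1` gives 2300 nM. Compound 2 `O=C(O)Cc1sc(C(c2ccccc2)c2ccccc2)nc1-c1ccccc1` gives 370 nM. Compound 3 `O=C(O)Cc1sc(C(c2ccc(F)cc2)c2ccc(F)cc2)nc1-c1cccc(F)c1` gives 18 nM, the lowest number of the three: compound 2 is the nearest, with a number higher by a margin beyond the scatter, and compound 1 is the furthest, again beyond the scatter. No two of the measured compounds differ in only one place, so none of these gaps can be assigned to a single change.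

Compound 4 `O=C(O)Cc1sc(C(c2ccc(F)cc2)c2ccc(F)cc2)nc1-c1ccnc(F)c1` has not yet been measured. It differs from compound 3 in one place, on an aromatic carbon of the five-membered aromatic ring with one nitrogen and one sulfur that forms the shared core: 2-fluoropyridin-4-yl in place of 3-fluorophenyl on an aromatic carbon. Both groups have seven heavy atoms and one fluorine; the group that enters brings one hydrogen-bond acceptor where the group that leaves had none.

Among the compounds with values here, the measured set contains no pair that isolates this kind of exchange, so the expectation rests on the small size of the change. The step of a 1.7-fold higher number from compound 3 to compound 4 (0.22 log units; within the scatter) is expected to be small, at the edge of the scatter, and if anything toward a higher number. Compound 4 is therefore estimated at 30 nM, with a range from 10 nM to 90 nM.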

Compound 4, half-maximal inhibitory concentration: 4.7 nM
For compound 4 the middle estimate is 6.4-fold (0.81 log units) above the measured one; measured number outside the range, below it.
By their numbers in this assay, from the lowest: compound 4; then compound 3; then compound 2; then compound 1.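

In this assay, the exchange of 3-fluorophenyl for 2-fluoropyridin-4-yl on this aromatic carbon of the shared core gives a 3.8-fold lower number from compound 3 to compound 4 (0.58 log units; beyond the scatter). Within the data shown here, this is the first change that can be read alone, and it shows that this position accepts a six-membered aromatic ring with a ring nitrogen, and the added hydrogen-bond acceptor that comes with it, without any loss; the number moves down by a margin beyond the scatter. Among these compounds, nothing measured here bears on the origin of this gain, and the single pair does not separate the ring nitrogen from the rest of the group.

On these data alone, whether the fluorine of the 2-fluoropyridin-4-yl group is needed remains open, as does how a chlorine atom, a methoxy group or an amine in its place would read at this position. Also open, as far as these compounds go, is whether the same exchange gives a step of similar size on the unfluorinated background of compound 2, since a single pair cannot show whether the gain carries over to other compounds.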